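This account rests on a few compounds, and the source may have more. Where it says the series, first, only, none or still open, it means among the compounds named here.

Measured in a functional assay on PC-3 cells (Homo sapiens) for cytotoxicity, read by MTT assay, with a stated time of 72 h; on this read-out higher numbers stand for weaker inhibition and lower numbers for stronger inhibition:

compound 1 `O=C(Nc1ccc(Oc2ccnc3[nH]ccc23)cc1)c1nn(-c2ccc(Br)cc2)ccc1=O`: 8040 nM
compound 2 `O=C(Nc1ccc(Oc2ccnc3[nH]ccc23)c(F)c1)c1nn(-c2ccc(Br)cc2)ccc1=O`: 40800 nM
compound 3 `Cn1ccc2c(Oc3ccc(NC(=O)c4nn(-c5ccc(Cl)cc5)ccc4=O)cc3)ccnc21`: for compound 3 only a limit is recorded, > 60000 nM

Compound 2 differs from compound 1 by fluoro in place of hydrogen on an aromatic carbon, and this change gave a 5.1-fold higher number from compound 1 to compound 2 (0.71 log units; beyond the scatter). The value of compound 3 is a limit of the assay and not a number: it sits at the limit of > 60000 nM in this assay, at which 1 of the 3 values shown sits. How the core of compound 3 differs from the core of compound 1 is not broken down here.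

Compound 4 `Cn1ccc2c(Oc3ccc(NC(=O)c4nn(-c5ccc(Cl)cc5)ccc4=O)cc3F)ccnc21` differs from compound 3 by fluoro in place of hydrogen on an aromatic carbon; the place lines are the same word for word, so this is the same change as that from compound 1 to compound 2. Since that change weakened inhibition, the step from compound 3 to compound 4 is expected to be a step that the limit leaves unreadable from compound 3 to compound 4, most likely leaving compound 4 at a limit. Compound 4 is estimated at 120000 nM, between 60000 nM and 400000 nM.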

Compound 4, half-maximal inhibitory concentration: > 60000 nM
Compound 4 ended at the assay's limit; the forecaster's own chance of this, stated with the estimate: 90%; the middle value does not contradict the limit.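

Compound 3 and compound 4 both stand at a limit and not at a number, so the step between them cannot be read: the limit of > 60000 nM in this assay, at which 2 of the 4 values shown sit.

Left open is whether fluoro in place of hydrogen on an aromatic carbon changes inhibition at all in this pair.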